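The source may report more compounds than this note shows. Statements on the series, on what has been measured and on what is new or still open speak of the compounds shown alone.

Measured in a functional assay on CCRF-CEM cells (Homo sapiens) for antiproliferative activity, with a stated time of 72 h; on this read-out lower numbers stand for stronger inhibition and higher numbers for weaker inhibition:
- Compound 1 `OC[C@H]1O[C@@H](n2cnc3c(NCc4cccc(F)c4)ncnc32)[C@H](O)[C@@H]1O`: 4000 nM
- Compound 2 `OC[C@H]1O[C@@H](n2cnc3c(NCc4ccccc4Br)ncnc32)[C@H](O)[C@@H]1O`: 12300 nM
- Compound 3 `COc1cccc(CNc2ncnc3c2ncn3[C@@H]2O[C@H](CO)[C@@H](O)[C@H]2O)c1`: 7600 nM

Compound 2, at 12300 nM, shares the upper end of this small set with compound 3: a 1.6-fold lower number from compound 2 to compound 3 (0.21 log units; within the scatter) stays within the scatter, while a 3.1-fold higher number from compound 1 to compound 2 (0.49 log units; beyond the scatter) goes beyond it.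

Compound 4 `OC[C@H]1O[C@@H](n2cnc3c(NCc4ccccc4OC(F)(F)F)ncnc32)[C@H](O)[C@@H]1O` keeps everything in compound 2 except for one change: trifluoromethoxy in place of bromo on an aromatic carbon, ortho to a large group (trifluoromethoxy in place of bromo on an aromatic carbon).

For the measured compounds named here, no measured step makes this exact exchange, so the evidence is indirect. The closest guide is the set of changes to the same aromatic ring. Among these, a 1.9-fold higher number from compound 1 to compound 3 (0.28 log units; within the scatter), methoxy in place of fluoro, stays within the scatter, and only the step from compound 1 to compound 2 exceeds it, and then modestly. In this assay, a step beyond the scatter is therefore not expected, and no direction is favoured with confidence.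

The estimated change is a 1.2-fold lower number from compound 2 to compound 4 (0.09 log units; within the scatter). Compound 4 is expected at 10000 nM, with an estimated range of 4000 nM to 25000 nM.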

Compound 4, half-maximal inhibitory concentration: > 166000 nM
Compound 4 ended at the assay's limit; the forecaster's own chance of this, stated with the estimate: 10%; middle value at least 16-fold (1.22 log units) away from the limit.
By their numbers in this assay, from the lowest: compounds 1, 3 and 2 (each within the scatter of the next, the first and the last beyond it). At a limit, above all of these: compound 4.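

In this assay, compound 4 gives no measured number but a limit of the assay: the limit of > 166000 nM in this assay, at which 1 of the 4 values shown sits. Even so, an at least 13-fold higher number from compound 2 to compound 4 (1.13 log units; beyond the scatter) is the largest step in this set, whereas the earlier steps on this aromatic ring stayed within the scatter or went modestly beyond it. It shows that activity at this place, ortho to a large group, depends strongly on the group it carries, and that trifluoromethoxy in place of bromo, five heavy atoms for one, is not a neutral exchange in this read-out.

The compounds shown leave open whether a methyl or a chloro group at this same place would stay near compound 2 or fall away like compound 4. They also leave open how trifluoromethoxy would behave at the place that fluoro holds in compound 1.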